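The compounds below may be only part of what the source reports. "The series", "measured", "known", "first", "only" and "open" are said of these compounds alone.

In an ADME assay on 184B5 cells (Homo sapiens) for antiproliferative activity, read by sulforhodamine B assay, with a stated time of 72 h (a higher number here means a weaker inhibitor, a lower number a stronger inhibitor), compound 1 `Fc1ccc(/C=C\c2cc3ccccc3nc2Cl)cc1` gives 35700 nM and compound 2 `COc1ccc2nc(Cl)c(/C=C\c3ccc(C(F)(F)F)cc3)cc2c1` gives 40000 nM. For the measured compounds named here, these two values lie within the scatter of each other, so compound 2 stands level with the only other measured compound, and both numbers sit in the same weak range. Compound 3 `COc1ccc2nc(Cl)c(/C=C\c3ccc(F)cc3)cc2c1` follows from compound 2 by placing fluoro in place of trifluoromethyl on an aromatic carbon. Going by the values given here, no measured pair isolates this change. Among the compounds with values here, the only guide is compound 1, which also carries a fluoro group and gives 35700 nM. No shift beyond the scatter is therefore expected in this assay. The expected step of a 1.2-fold lower number from compound 2 to compound 3 (0.08 log units; within the scatter) is estimated to be small, and its direction is uncertain. The estimate for compound 3 is 33000 nM, with an expected range from 14000 nM to 70000 nM.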

Compound 3, half-maximal inhibitory concentration: 19200 nM
Compound 3: the middle estimate sits 1.7-fold (0.24 log units) above what was measured; low and high end bracket the measured number.
By their numbers in this assay, from the lowest: compounds 3, 1 and 2 (each within the scatter of the next, the first and the last beyond it).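

In this assay the group on the aromatic carbon para to a large group now has a measured effect: fluoro in place of trifluoromethyl gives a 2.1-fold lower number from compound 2 to compound 3 (0.32 log units; beyond the scatter) and this modest step is the only one here beyond the scatter. Methoxy in place of hydrogen on an aromatic carbon gives a 1.9-fold lower number from compound 1 to compound 3 (0.27 log units; within the scatter) and so stays within the scatter, which means that this pair shows no effect of the methoxy group that can be told apart from assay noise. The data offer no measurement that accounts for the step from trifluoromethyl to fluoro.

The compounds shown leave open whether the step from trifluoromethyl to fluoro holds without the methoxy group. They also leave open how an amine or a carboxylic acid would behave on the same aromatic carbon.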